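The compounds below may be only part of what the source reports. "The series", "measured", "known", "first", "only" and "open" are said of these compounds alone.

Measured compounds:
- compound 1, `Cc1cc(C)cc(S(=O)(=O)c2c(C(=O)NCc3n[nH]c4ccccc34)[nH]c3ccc(Cl)cc23)c1`: > 50700 nM in an ADME assay on MT4 cells (Homo sapiens) for cytotoxicity, read by MTT assay; a lower number here means that less compound is tolerated, a higher number that more compound is tolerated
- compound 2, `Cc1cc(C)cc(S(=O)(=O)c2c(C(=O)NC(C)C(=O)NC(C)c3ccccc3)[nH]c3ccc(Cl)cc23)c1`: 21700 nM in this assay

Compound 1 returns no number in this assay, only a limit, > 50700 nM; this is the point (the limit of > 50700 nM in this assay, at which 1 of the 2 values shown sits). For the measured compounds named here, compound 2 is the single compound of the pair that gives an actual number in this assay, 21700 nM. Going by the values given here, no pair of measured compounds here differs in one place, so no measured step is available against which to set the change that follows.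

Compound 3, `Cc1cc(C)cc(S(=O)(=O)c2c(C(=O)NC(C)C(=O)NCc3ccncc3)[nH]c3ccc(Cl)cc23)c1`, is still to be measured in this assay. It differs from compound 2 by (pyridin-4-yl)methyl in place of 1-phenylethyl on an amide-type nitrogen. The change sits on an amide-type nitrogen whose other neighbour is a carbonyl carbon; a (pyridin-4-yl)methyl group enters where a 1-phenylethyl group leaves.

Nothing measured here indicates how this assay answers to such a change. The expectation is a step from compound 2 to compound 3 of a 1.4-fold higher number from compound 2 to compound 3 (0.14 log units; within the scatter), essentially none beyond the scatter, with any drift more likely upward than downward. Compound 3 is therefore estimated at 30000 nM in this assay, within 12000 nM to 75000 nM.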

Compound 3, half-maximal cytotoxic concentration: 19500 nM
The estimate for compound 3 lay 1.5-fold (0.19 log units) above the measured number, within the range that was stated.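

For the compounds shown here, on an amide-type nitrogen, (pyridin-4-yl)methyl in place of 1-phenylethyl gives the only single-place step in this assay so far: a 1.1-fold lower number from compound 2 to compound 3 (0.05 log units; within the scatter). For this pair, then, a carbon-only aromatic ring giving way to a ring with a hetero atom, together with the entry of a hydrogen-bond acceptor, leaves the cytotoxic concentration without a change beyond the scatter. The wider replacement on an amide-type nitrogen gives an at least 2.6-fold lower number from compound 1 to compound 3 (0.41 log units; beyond the scatter), but it changes more than one feature and its size is bounded by a limit rather than fixed by a number: the limit of > 50700 nM in this assay, at which 1 of the 3 values shown sits.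

A benzyl group on the same nitrogen would separate the contribution of the ring nitrogen from that of the branching methyl of 1-phenylethyl, which compound 2 and compound 3 change together. As far as these compounds go, whether this position stays as flat in this assay without an aromatic ring, or with a carboxylic acid or a simple alkyl chain in place of the (pyridin-4-yl)methyl group, remains open, and so does the true number for compound 1.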